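The source may report more compounds than this note shows. Statements on the series, on what has been measured and on what is new or still open speak of the compounds shown alone.

The study concerns three measured compounds sharing one core, all tested in an ADME assay on BHK cells (Mesocricetus auratus) for cytotoxicity, read by XTT assay; on this read-out lower numbers stand for higher toxicity in this test and higher numbers for lower toxicity in this test. Compound 1 `c1ccc(CCCC[C@@H]2COCCO2)cc1` gives in this assay > 1000000 nM, which is a limit of the assay rather than a number. Compound 2 `O=C(O)C[C@H]1COCCO1` gives in this assay > 5000000 nM, again only a limit. Compound 3 `ICC[C@@H]1COCCO1` gives in this assay > 1000000 nM, also a limit. Compound 3 therefore stands where every measured compound stands: at a limit, with no number recorded, as seen in the limit of > 1000000 nM in this assay, at which 2 of the 3 values shown sit, and (the limit of > 5000000 nM in this assay, at which 1 of the 3 values shown sits). For the measured compounds named here, no step between measured compounds differing in a single place exists here.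

Compound 4 `OCCC[C@@H]1COCCO1` has not yet been measured. It differs from compound 3 by hydroxymethyl in place of iodo on a saturated chain carbon, two bonds along the chain from a saturated ring carbon. Going by the values given here, with every measured value sitting at a limit, there is no step on which to ground a change in either direction, so no step beyond the scatter is expected. In this assay compound 4 is expected to stay at a limit, the estimated step being a step that the limit leaves unreadable from compound 3 to compound 4. Compound 4 is estimated at 1500000 nM, in a range from 500000 nM to 5000000 nM.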

Compound 4, half-maximal cytotoxic concentration: > 1000000 nM
Compound 4: no number, only a limit; the forecaster's own chance of this, stated with the estimate: 85%; the middle value lies beyond the limit too.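

For the compounds shown here, compound 3 and compound 4 both sit at a limit in this assay, so no step between them can be read. The compounds shown leave open what number any of them would reach in this assay, and whether hydroxymethyl in place of iodo changes it.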